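From an aryl thiourea tail to an acyl chain

A few compounds are considered here, and "the series" means these few. Any claim that something is new, unique, unknown or untested is made for them only; others in the source may bear on it.

Compound 1 `CCCn1c(=O)c2nc(-c3ccc(OCC(=O)NCCN=C(S)Nc4ccc(N=C=S)cc4)cc3)[nH]c2n(CCC)c1=O` gives 6.6 nM in an assay on brain for binding affinity to adenosine receptor A1 (Rattus norvegicus), read by radioligand binding (a higher number here means a weaker inhibitor, a lower number a stronger inhibitor), and compound 2 `CCCn1c(=O)c2nc(-c3ccc(OCC(=O)NCCN=C(S)Nc4ccc(F)cc4)cc3)[nH]c2n(CCC)c1=O` gives 15.5 nM in this assay, so that a 2.3-fold higher number from compound 1 to compound 2 (0.37 log units; beyond the scatter). Among the measured compounds shown here, compound 2 thus holds the higher of the two numbers measured so far. Compound 3 `CCCn1c(=O)c2nc(-c3ccc(OCC(=O)NCCNC(=O)CCCCC(C)=O)cc3)[nH]c2n(CCC)c1=O` differs from compound 2 as follows: a group of 10 heavy atoms (7 carbon, 1 nitrogen, 2 oxygen; no ring) in place of a group of 11 heavy atoms (7 carbon, 2 nitrogen, 1 fluorine, 1 sulfur; one six-membered aromatic ring of carbon only), on a saturated chain carbon, two bonds along the chain from an amide-type nitrogen. For the measured compounds named here, the only measured step, a 2.3-fold higher number from compound 1 to compound 2 (0.37 log units; beyond the scatter), altered a substituent on the aromatic ring that now leaves entirely, so it bears only loosely on this change. Compound 3 is therefore expected to stay near compound 2, with a 1.0-fold lower number from compound 2 to compound 3 (0.01 log units; within the scatter) as the estimated step, giving an estimate of 15 nM (range 4 nM to 55 nM).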

Compound 3, inhibition constant: 44 nM
Compound 3: the middle estimate sits 2.9-fold (0.47 log units) below what was measured; the measured number falls inside the stated range.
By their numbers in this assay, from the lowest: compound 1; then compound 2; then compound 3.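

At this position on the saturated chain carbon, the aromatic ring can leave altogether at modest cost: in this assay, the ((4-acetylbutyl)carbonyl)amino group in place of the aryl thiourea tail gives a 2.8-fold higher number from compound 2 to compound 3 (0.45 log units; beyond the scatter) and keeps the number within reach of compound 2. The earlier step touched only a substituent on that ring, so it could not show that the tail tolerates a ringless acyl chain. Nothing in hand accounts for this step. A single acyl chain cannot separate the loss of the ring from the gain of the chain. It also leaves open whether a carboxylic acid, an amine or a longer chain in place of the terminal acetyl would give a lower number.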